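Formyl to methoxyphenyl: what compound 1 stands to lose

The compounds below may be only part of what the source reports. "The series", "measured", "known", "first", "only" and "open" are said of these compounds alone.

Compound 1 `O=Cc1ccc(-c2cn3ccnc3c(-c3ccc4ncn(C5CCCCC5)c4c3)n2)cc1`: 54.5%
Compound 2 `Fc1ccc(-c2cn3ccnc3c(-c3ccc4ncn(C5CCCCC5)c4c3)n2)cc1`: 2.36%
Compound 3 `CC(=O)c1ccc(-c2cn3ccnc3c(-c3ccc4ncn(C5CCCCC5)c4c3)n2)cc1`: 8.6%

In a functional assay on NCI-H23 cells (Homo sapiens) for inhibition, read by sulforhodamine B assay, with a stated time of 48 h, tested at 10 uM (a lower number here means less inhibition, a higher number more inhibition at the concentration tested (going by the name of the read-out)), compound 1 gives the highest of the three numbers, the nearest being compound 3, and both measured steps away from it are large drops: a number 52.1 percentage points lower from compound 1 to compound 2 (beyond the scatter) and a number 45.9 percentage points lower from compound 1 to compound 3 (beyond the scatter). Compound 2 and compound 3 sit close together, a number 6.2 percentage points higher from compound 2 to compound 3 (within the scatter). Compound 4 `COc1ccccc1-c1cn2ccnc2c(-c2ccc3ncn(C4CCCCC4)c3c2)n1` differs from compound 1 in one place: 2-methoxyphenyl in place of 4-formylphenyl on an aromatic carbon. Both measured steps bear on it, since each alters the formyl group that compound 4 loses entirely, and each was large and downward. Compound 4 is therefore expected to fall well short of compound 1, with an estimated step of a number 44.5 percentage points lower from compound 1 to compound 4 (beyond the scatter). The estimated value for compound 4 is 10%, within a range of 0% to 35%.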

Compound 4, a percentage reported as inhibition, at one concentration (the size of the read-out at that concentration, not a potency): 2.79%
For compound 4 the middle estimate is 7.2 percentage points above the measured one; low and high end bracket the measured number.
By their numbers in this assay, from the lowest: compounds 2, 4 and 3 (each within the scatter of the next); then compound 1.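

Swapping 4-formylphenyl for 2-methoxyphenyl, a group with the same counts of heavy atoms and hydrogen-bond acceptors, still brings a number 51.7 percentage points lower from compound 1 to compound 4 (beyond the scatter), so matching those counts does not preserve the number at this position. The new group lands with the other two replacements, at a number 5.8 percentage points lower from compound 3 to compound 4 (within the scatter) and a number 0.4 percentage points higher from compound 2 to compound 4 (within the scatter), leaving 4-formylphenyl alone apart among the four groups shown. Nothing available here accounts for this.

Going by these compounds, it remains open whether a nitrile or a carboxylic acid in place of the formyl would keep the number of compound 1. Compound 4 alters the group and its place on the phenyl ring together, so these two changes cannot be separated.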